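Swapping the ring-bearing side chain of compound 2

The compounds below may be only part of what the source reports. "The series", "measured", "known", "first", "only" and "open" are said of these compounds alone.

Measured in a functional assay on NCI-H460 cells (Homo sapiens) for cytotoxicity, read by MTT assay, with a stated time of 96 h; a higher number here means a weaker inhibitor, a lower number a stronger inhibitor:
- compound 1 `COc1ncc(-c2cc(OC)c3nc(N)nc(C)c3c2)cc1NS(=O)(=O)c1ccc(F)cc1F` gives 280 nM
- compound 2 `COc1ncc(-c2cc(OCC3CCOCC3)c3nc(N)nc(C)c3c2)cc1NS(=O)(=O)c1ccc(F)cc1F` gives 21 nM

Of the two measured compounds, compound 2 has the lower number, at 21 nM. Compound 3 `COc1ncc(-c2cc(OC3CCN(C)CC3)c3nc(N)nc(C)c3c2)cc1NS(=O)(=O)c1ccc(F)cc1F` carries 1-methylpiperidin-4-yl in place of (oxan-4-yl)methyl on an oxygen on an aromatic ring. Each group holds one six-membered non-aromatic ring with 1 hetero atom.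

Going by the values given here, the only measured step is large: a 13-fold lower number from compound 1 to compound 2 (1.12 log units; beyond the scatter). It brought in the oxan-4-yl group, so it gives only indirect guidance. Among the compounds with values here, no measured step exchanges one of these rings for the other, and compound 3 still has a ring at this place. A step within the scatter is therefore expected in this assay, leaning slightly towards a higher number. The estimated step is a 1.7-fold higher number from compound 2 to compound 3 (0.22 log units; within the scatter). For compound 3 the expected value is 35 nM, with an estimated range of 10 nM to 120 nM.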

Compound 3, half-maximal inhibitory concentration: 660 nM
Compound 3: the middle estimate sits 19-fold (1.28 log units) below what was measured; measured number above the stated range.
By their numbers in this assay, from the lowest: compound 2; then compound 1; then compound 3.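

In this assay, a six-membered non-aromatic ring on this oxygen does not by itself give a low number: 1-methylpiperidin-4-yl gives a 31-fold higher number from compound 2 to compound 3 (1.50 log units; beyond the scatter) even though it matches (oxan-4-yl)methyl in heavy atoms, hydrogen-bond donors and hydrogen-bond acceptors. Even the small methyl group does better here, since its replacement gives a 2.4-fold higher number from compound 1 to compound 3 (0.37 log units; beyond the scatter) in the same assay, so the gain seen with (oxan-4-yl)methyl does not extend to every ring-bearing group at this place. No measured evidence accounts for this difference.

The step from compound 2 to compound 3 changes the ring's hetero atom from oxygen to nitrogen and also removes the carbon link to the ring, and the compounds shown leave these two changes tangled. Either (1-methylpiperidin-4-yl)methyl or oxan-4-yl on the same oxygen would differ from compound 2 in only one of them.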